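This account rests on a few compounds, and the source may have more. Where it says the series, first, only, none or still open, it means among the compounds named here.

Compound 1, `O=Cc1ccc(-c2cn3ccnc3c(-c3ccc4ncn(C5CCCCC5)c4c3)n2)cc1`, and compound 2, `O=Cc1ccc(-c2cn3ccnc3c(-c3ccc4ncn(Cc5ccccc5)c4c3)n2)cc1`, share one core and differ in a single place: benzyl in place of cyclohexyl on an aromatic nitrogen. In a functional assay on DU-145 cells (Homo sapiens) for inhibition, read by sulforhodamine B assay, with a stated time of 48 h, tested at 10 uM (a higher number here means more inhibition at the concentration tested (going by the name of the read-out), a lower number less inhibition), compound 1 gives 24.3%. In the same measurement compound 2 gives 24.3%, so the step of no change at the digits printed from compound 1 to compound 2 (within the scatter) shows that this exchange left the read-out where it was.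

Compound 3, `c1cn2cc(-c3ccc4c(c3)ncn4C3CCCCC3)nc(-c3ccc4ncn(C5CCCCC5)c4c3)c2n1`, is built on a different core, carrying the same cyclohexyl-bearing ring system twice; how its core differs from that of compound 1 is not broken down here. In this assay compound 3 gives 8.72%, the lowest of the three numbers and beyond the scatter from both others.

Compound 4, `c1ccc(Cn2cnc3ccc(-c4nc(-c5ccc6c(c5)ncn6C5CCCCC5)cn5ccnc45)cc32)cc1`, has not yet been measured. It differs from compound 3 by benzyl in place of cyclohexyl on an aromatic nitrogen, the same change as from compound 1 to compound 2, made at a place described in identical words. Because that earlier exchange produced no change at the digits printed from compound 1 to compound 2 (within the scatter), the step expected for compound 4 is a number 0.3 percentage points higher from compound 3 to compound 4 (within the scatter), close to none. Compound 4 is therefore estimated to give about 9%, most likely between 0% and 22%.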

Compound 4, a percentage reported as inhibition, at one concentration (the size of the read-out at that concentration, not a potency): -28.2%
For compound 4 the middle estimate is 37.2 percentage points above the measured one; the whole stated range lies above it.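

Exchanging cyclohexyl for benzyl on the aromatic nitrogen does not behave the same way on these two cores in this assay: the same change on two cores in this assay, no change at the digits printed (within the scatter) from compound 1 to compound 2 and a number 36.9 percentage points lower (beyond the scatter) from compound 3 to compound 4, 36.9 percentage points apart, beyond the scatter of two such steps.

The exchange gives a number 36.9 percentage points lower from compound 3 to compound 4 (beyond the scatter) so the flat result seen on the core of compound 1 cannot be relied on as a forecast for the core of compound 3. For the compounds shown here, with only one pair on each core, this shows that the outcome of the exchange depends on the core in these four compounds, but it does not show why, and it sets no rule for any further core.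

The compounds shown leave open how other groups on that aromatic nitrogen would behave on either core, such as a methyl, a longer alkyl chain or a chain ending in an amine. They also leave open what a benzyl in place of the remaining cyclohexyl of compound 4 would do.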